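A few compounds are considered here, and "the series" means these few. Any claim that something is new, unique, unknown or untested is made for them only; others in the source may bear on it.

The measured compounds:

Compound 1, `C[C@@H]1CN(c2sc(CN(C)C)nc2-c2nc3ccccc3[nH]2)CCN1C(=O)Cn1cnc2cccnc21`: in an assay on blood for inhibition of C-X-C chemokine receptor type 3 (Homo sapiens), with a stated time of 30 min (a lower number here means a stronger inhibitor, a higher number a weaker inhibitor), compound 1 gives 1150 nM.
Compound 2, `CCOc1ncc(-c2nc(C(F)(F)F)sc2N2CCN(C(=O)Cn3ccc4cnccc43)[C@H](C)C2)cn1`: in this assay compound 2 gives 25 nM.

Among the measured compounds shown here, of the two numbers, compound 2 stands lowest, and the only other compound, compound 1, gives a far higher number, well beyond the usual scatter of this assay. The two differ in many places at once, so no single change can be read from them.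

Compound 3, `CCOc1ncc(-c2nc(C(F)(F)F)sc2N2CCN(C(=O)Cn3cc(Cl)cn3)[C@H](C)C2)cn1`, has not yet been measured. It is built from compound 2 by one change: a group of 6 heavy atoms (3 carbon, 2 nitrogen, 1 chlorine; one five-membered aromatic ring with 2 hetero atoms) in place of a group of 9 heavy atoms (7 carbon, 2 nitrogen; one five-membered aromatic ring with 1 hetero atom, one six-membered aromatic ring with 1 hetero atom), on a saturated chain carbon bound to a carbonyl carbon. For the measured compounds named here, no pair of measured compounds shows the effect of such a swap at this position, so nothing in the data points to a direction. A modest weakening seems the more likely outcome, and this expected step is a 2.4-fold higher number from compound 2 to compound 3 (0.38 log units; beyond the scatter). Compound 3 is therefore expected to give about 60 nM, with a range from 15 nM to 250 nM.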

Compound 3, half-maximal inhibitory concentration: 245 nM
The estimate for compound 3 lay 4.1-fold (0.61 log units) below the measured number; measured number inside the range.
By their numbers in this assay, from the lowest: compound 2; then compound 3; then compound 1.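

Among the compounds shown here, this is the first pair of compounds that differ in one place only, so the group on a saturated chain carbon bound to a carbonyl carbon can now be judged on its own. In this assay, putting 4-chloro-1H-pyrazol-1-yl in place of the two-ring group gives a 9.8-fold higher number from compound 2 to compound 3 (0.99 log units; beyond the scatter) and this step lies beyond the usual scatter. The position is therefore sensitive to the group it carries, and this smaller single-ring group does not match the two-ring group of compound 2, though no measurement here explains the difference.

Going by these compounds, the swap changes the ring system and adds a chlorine at once, so the share of each remains open. A pyrazole without the chlorine, or one carrying a methyl group or a nitrile in its place, would help to separate the two.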